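The compounds below may be only part of what the source reports. "The series", "measured", "known", "first", "only" and "open" are said of these compounds alone.

Measured in a functional assay on PC-3 cells (Homo sapiens) for cytotoxicity; on this read-out higher numbers stand for an effect only at larger amounts of compound and lower numbers for an effect already at smaller amounts:
Compound 1 `COC1=C(C)C(=O)/C(=C(O)/C=C/c2ccc(Br)cc2)C(=O)C1(C)C`: 17.7 ug/mL
Compound 2 `COC1=C(C)C(=O)/C(=C(O)/C=C/c2ccccc2OC)C(=O)C1(C)C`: 15.6 ug/mL
Compound 3 `COC1=C(C)C(=O)/C(=C(O)/C=C/c2ccc(F)cc2)C(=O)C1(C)C`: 7.2 ug/mL

Compound 3 has the lowest number of the three, and its gaps to the other two lie beyond the scatter. Next comes compound 4 `COC1=C(C)C(=O)/C(=C(O)/C=C/c2ccc(C)cc2)C(=O)C1(C)C` with methyl in place of fluoro on an aromatic carbon. For the measured compounds named here, no measured step exchanges these two groups. The closest is a 2.5-fold lower number from compound 1 to compound 3 (0.39 log units; beyond the scatter) for fluoro in place of bromo on an aromatic carbon, and a 2.2-fold lower number from compound 2 to compound 3 (0.34 log units; beyond the scatter) is of similar modest size. The remaining step of a 1.1-fold lower number from compound 1 to compound 2 (0.05 log units; within the scatter) stays within the scatter. With compound 3 at the low end of a 2.5-fold lower number from compound 1 to compound 3 (0.39 log units; beyond the scatter) in this series, a move to a higher number in this assay is expected, smaller than those two steps and possibly inside the scatter. The estimate is a 1.5-fold higher number from compound 3 to compound 4 (0.18 log units; within the scatter) as the expected step. For compound 4 the estimated value is 11 ug/mL with an expected range from 5.5 ug/mL to 22 ug/mL in the same read-out.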

Compound 4, concentration for half-maximal effect: 8.2 ug/mL
The estimate for compound 4 lay 1.3-fold (0.13 log units) above the measured number; the measured number falls inside the stated range.
By their numbers in this assay, from the lowest: compounds 3, 4, 2 and 1 (each within the scatter of the next, the first and the last beyond it).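

In this assay, 4-fluorophenyl and 4-methylphenyl do not separate: a 1.1-fold higher number from compound 3 to compound 4 (0.06 log units; within the scatter) stays within the scatter, so the low end of the series is no longer held by fluoro alone. Methyl also parts from bromo at this carbon, para to a large group, with a 2.2-fold lower number from compound 1 to compound 4 (0.33 log units; beyond the scatter) lying beyond the scatter, while a 1.9-fold lower number from compound 2 to compound 4 (0.28 log units; within the scatter) stays within it, so the 2-methoxyphenyl compound is not clearly apart from compound 4. No measurement is available that bears on why bromo reads differently from fluoro and methyl here.

The compounds shown leave open whether chloro would fall with fluoro and methyl or with bromo. On these data alone, how an amine, a carboxylic acid or a longer chain would read at this carbon also remains open.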